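Working notes: from compound 2 to compound 3

A few compounds are considered here, and "the series" means these few. Any claim that something is new, unique, unknown or untested is made for them only; others in the source may bear on it.

For the measured compounds named here, in a functional assay on MDA-MB-231 cells (Homo sapiens) for antiproliferative activity, with a stated time of 4 days (on this read-out lower numbers stand for stronger inhibition and higher numbers for weaker inhibition), compound 1 `CCCCc1ccc2[nH]c(-c3ccc(OC)cc3)c(/C=N/O)c2c1` gives 40 nM and compound 2 `CCCCc1ccc2[nH]c(-c3ccc(OC)cc3)c(/C=N/NC(=O)c3ccc(F)cc3)c2c1` gives 19 nM, the lower of the two numbers so far. Compound 3 `CCCCc1ccc2[nH]c(-c3ccc(OC)cc3)c(/C=N/NC(=O)c3ccccc3OC)c2c1` keeps the shared core and the carbonyl, and carries 2-methoxyphenyl in place of 4-fluorophenyl on a carbonyl carbon. Going by the values given here, no measured pair varies this group, so the data give no direction for the change. Among the compounds with values here, the one measured step, a 2.1-fold lower number from compound 1 to compound 2 (0.32 log units; beyond the scatter), was modest, and it exchanged hydroxy for the whole ((4-fluorophenyl)carbonyl)amino group, a larger change than the present one. A smaller shift is therefore expected here, with the estimated step being a 1.3-fold higher number from compound 2 to compound 3 (0.12 log units; within the scatter), which would not clearly separate the two compounds. The estimate for compound 3 is 25 nM, with an expected range of 8 nM to 75 nM.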

Compound 3, half-maximal inhibitory concentration: 21 nM
Compound 3: middle estimate off by 1.2-fold (0.08 log units), on the high side; low and high end bracket the measured number.
By their numbers in this assay, from the lowest: compounds 2, 3 and 1 (each within the scatter of the next, the first and the last beyond it).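

For the compounds shown here, on the carbonyl carbon, 2-methoxyphenyl stands in for 4-fluorophenyl with a 1.1-fold higher number from compound 2 to compound 3 (0.04 log units; within the scatter), so in this assay this position accepts either group without a separable difference, which no earlier pair could show. With ((2-methoxyphenyl)carbonyl)amino in place of hydroxy on the double-bonded nitrogen, the result is a 1.9-fold lower number from compound 1 to compound 3 (0.28 log units; within the scatter), so this exchange, unlike the one carrying 4-fluorophenyl, does not clear the scatter, though the two aryl groups themselves remain indistinguishable. Nothing available explains why the two groups read alike.

Open, as far as these compounds go, is whether this tolerance extends to groups of a different kind on the carbonyl carbon, such as an aminophenyl, a carboxylic acid-bearing phenyl or a longer alkyl chain. Also open, from the compounds shown here alone, is whether 4-methoxyphenyl or unsubstituted phenyl would read the same as 2-methoxyphenyl.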